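This account rests on a few compounds, and the source may have more. Where it says the series, first, only, none or still open, it means among the compounds named here.

Measured compounds:
compound 1 `COc1nc(N)nc2c1c(-c1ccccc1)cn2[C@@H]1O[C@H](CO)[C@@H](O)[C@H]1O`: in a functional assay on CEM-DNR-bulk cells (Homo sapiens), read by MTT assay, with a stated time of 72 h (on this read-out lower numbers stand for stronger inhibition and higher numbers for weaker inhibition), compound 1 gives > 20000 nM, which is a limit of the assay and not a number.
compound 2 `C#Cc1cn([C@@H]2O[C@H](CO)[C@@H](O)[C@H]2O)c2nc(N)nc(OC)c12`: compound 2 gives > 20000 nM, again a limit.
compound 3 `COc1ncnc2c1c(-c1ccccc1)cn2[C@@H]1O[C@H](CO)[C@@H](O)[C@H]1O`: compound 3 gives > 20000 nM, also a limit.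

All three values sit at the limit of > 20000 nM in this assay, at which 3 of the 3 values shown sit. From compound 1 to compound 2 the change is ethynyl in place of phenyl on an aromatic carbon; the step is a step that the two limits leave unreadable from compound 1 to compound 2. The two cores differ by hydrogen in place of amino on an aromatic carbon, and that step is a step that the two limits leave unreadable from compound 1 to compound 3.

Compound 4 `C#Cc1cn([C@@H]2O[C@H](CO)[C@@H](O)[C@H]2O)c2ncnc(OC)c12` has not yet been measured. It differs from compound 3 by ethynyl in place of phenyl on an aromatic carbon, the same kind of change as from compound 1 to compound 2; the place differs only in that there the ring atom bears a 3,4-dihydroxy-5-(hydroxymethyl)oxolan-2-yl group (9 heavy atoms), here a group of 9 heavy atoms. In this assay the step from compound 3 to compound 4 is expected to be a step that the limit leaves unreadable from compound 3 to compound 4, beside the earlier one, because compound 1 and compound 2 both sit at the limit of > 20000 nM in this assay, at which 3 of the 3 values shown sit. For compound 4 the estimate is 25000 nM, expected to fall between 8000 nM and 60000 nM.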

Compound 4, half-maximal inhibitory concentration: 3490 nM
Estimate against measurement, compound 4: 7.2-fold (0.86 log units) above; the whole stated range lies above it.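

In this assay, ethynyl in place of phenyl on an aromatic carbon gives an at least 5.7-fold lower number from compound 3 to compound 4 (0.75 log units; beyond the scatter), and hydrogen in place of amino on an aromatic carbon gives an at least 5.7-fold lower number from compound 2 to compound 4 (0.75 log units; beyond the scatter); both sizes are bounds, since compound 2 and compound 3 sit at a limit of the assay and carry no number. Of the four compounds, only compound 4, which combines ethynyl with the core lacking the amino group, gives a number, but this single pair establishes no rule for the change on other cores. The same change on the core of compound 1 cannot be read, so whether it has any effect there stays unknown, because both of those compounds sit at the limit: the limit of > 20000 nM in this assay, at which 3 of the 4 values shown sit.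

Going by these compounds, whether a propynyl group or a nitrile on that aromatic carbon also gives a number on the core of compound 3 remains open. Also open, on these data alone, is how an amine in place of the amino group would behave on the core of compound 1.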